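A few compounds are considered here, and "the series" means these few. Any claim that something is new, unique, unknown or untested is made for them only; others in the source may bear on it.

Measured so far in a functional assay for inhibition, with Homo sapiens as the target; on this read-out higher numbers stand for weaker inhibition and lower numbers for stronger inhibition:
- compound 1 `O=C(O)CCCCCCn1nc(-c2ccccc2)c(-c2ccccc2)c1-c1ccccc1`: 22400 nM
- compound 2 `O=C(O)CCCCCCCn1nc(-c2ccccc2)c(-c2ccccc2)c1-c1ccccc1`: 3400 nM
- compound 3 `O=C(O)CCCCCCn1cc(-c2ccccc2)c(-c2ccccc2)n1`: > 92000 nM

Compound 3 has no exact number, as it stands at the limit of > 92000 nM in this assay, at which 1 of the 3 values shown sits. Compound 4 `O=C(O)CCCCCCCn1cc(-c2ccccc2)c(-c2ccccc2)n1` differs from it by one change, carboxymethyl in place of carboxy on a saturated chain carbon (carboxymethyl in place of carboxy on a saturated chain carbon, six bonds along the chain from an aromatic nitrogen).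

The same change has been measured once, as a 6.6-fold lower number from compound 1 to compound 2 (0.82 log units; beyond the scatter). The other measured step, an at least 4.1-fold higher number from compound 1 to compound 3 (0.61 log units; beyond the scatter), is hydrogen in place of phenyl on an aromatic carbon, and it links the two pairs. Compound 4 carries that same replacement relative to compound 2 at 3400 nM, so a higher number than that is expected. A similar move towards a lower number in this assay is therefore expected, resting on one pair and on a limit. The expected step is an at least 3.6-fold lower number from compound 3 to compound 4 (0.56 log units; beyond the scatter). For compound 4 the estimated value is 25000 nM, with an expected range of 9000 nM to 90000 nM.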

Compound 4, half-maximal inhibitory concentration: > 85000 nM
Compound 4 gave a limit, no number; the forecaster's own chance of this, stated with the estimate: 25%; middle value at least 3.4-fold (0.53 log units) from the limit.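

In this assay compound 4 also sits at a limit (> 85000 nM). The step from compound 3 cannot be read because both values are limits, so the gain from the longer chain seen on the core of compound 1 is neither confirmed nor ruled out once the phenyl is gone. Hydrogen in place of phenyl gives an at least 25-fold higher number from compound 2 to compound 4 (1.39 log units; beyond the scatter) on the longer chain, and the two cores compare as follows: the same change on two cores in this assay, an at least 4.1-fold higher number (0.61 log units; beyond the scatter) from compound 1 to compound 3 and an at least 25-fold higher number (1.39 log units; beyond the scatter) from compound 2 to compound 4; the limit leaves it open whether they differ

From the compounds shown here alone, whether a still longer chain restores measurable inhibition without that phenyl stays open. So does the effect of a methyl group in its place.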